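The compounds below may be only part of what the source reports. "The series", "measured", "known", "first", "only" and "open" are said of these compounds alone.

The measured compounds:

Compound 1, `COc1nc(C)c(Nc2nc(Cl)cn([C@H](COC(=O)Nc3ccccc3)C3CC3)c2=O)cc1C`; in an assay on frontal cortex for displacement of a labelled ligand from corticotropin-releasing factor receptor 1 (Rattus norvegicus), with a stated time of 2 h (on this read-out higher numbers stand for weaker inhibition and lower numbers for stronger inhibition), compound 1 gives 1.5 nM.
Compound 2, `COc1nc(C)c(Nc2nc(Cl)cn([C@H](COC(=O)Nc3ccccc3Cl)C3CC3)c2=O)cc1C`; in this assay compound 2 gives 1.5 nM.
Compound 3, `COc1nc(C)c(Nc2nc(Cl)cn([C@H](COC(=O)Nc3cccnc3)C3CC3)c2=O)cc1C`; in this assay compound 3 gives 10 nM.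

Compound 3 has the highest number of the three. Its two measured neighbours both lie beyond the scatter from it: a 6.7-fold higher number from compound 1 to compound 3 (0.82 log units; beyond the scatter) and a 6.7-fold higher number from compound 2 to compound 3 (0.82 log units; beyond the scatter). Between compound 1 and compound 2 the step is no change at the digits printed from compound 1 to compound 2 (within the scatter).

Compound 4, `COc1nc(C)c(Nc2nc(Cl)cn([C@H](COc3cc(Br)ccn3)C3CC3)c2=O)cc1C`, has not yet been measured. It differs from compound 3 in one place: 4-bromopyridin-2-yl in place of (pyridin-3-yl)carbamoyl on an oxygen on a saturated carbon. None of the three measured steps covers this change; all of them keep the carbamate and vary only the aryl on its nitrogen. The move back from the pyridin-3-yl carbamate to the phenyl carbamates gave a modest gain, which suggests the pyridin-3-yl carbamate is the weakest of the three variants, but it says nothing direct about an ether. The step from compound 3 to compound 4 is therefore expected, with low confidence, to be a modest lowering, a 2.0-fold lower number from compound 3 to compound 4 (0.30 log units; within the scatter). Compound 4 is expected to give roughly 5 nM, within a range from 1 nM to 30 nM.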

Compound 4, half-maximal inhibitory concentration: 1.5 nM
Estimate against measurement, compound 4: 3.3-fold (0.52 log units) above; low and high end bracket the measured number.
By their numbers in this assay, from the lowest: compounds 1, 2 and 4 (each within the scatter of the next); then compound 3.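

The carbamate is not required at this oxygen in this assay: replacing (pyridin-3-yl)carbamoyl with 4-bromopyridin-2-yl gives a 6.7-fold lower number from compound 3 to compound 4 (0.82 log units; beyond the scatter), so a group with no carbamoyl and no hydrogen-bond donor is tolerated here. The ether also matches both phenyl carbamates, with no change at the digits printed from compound 1 to compound 4 (within the scatter) and no change at the digits printed from compound 2 to compound 4 (within the scatter), so this site accepts two different kinds of linkage with no difference in the number beyond the scatter. Nothing given here explains the gain over the pyridin-3-yl carbamate.

What the bromine contributes remains open, as the compounds shown include no unsubstituted pyridin-2-yl ether and no analogue with chloro or nitrile in its place. Also open, from the compounds shown here alone, is how a simple phenyl ether, a methyl ether or the free alcohol would read at this oxygen.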